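A few compounds are considered here, and "the series" means these few. Any claim that something is new, unique, unknown or untested is made for them only; others in the source may bear on it.

In a functional assay on MIA PaCa-2 cells (Homo sapiens) for inhibition, read by MTT assay, with a stated time of 48 h, tested at 10 uM (a lower number here means less inhibition of growth, a higher number more inhibition of growth at the concentration tested), compound 1 `Cc1cc(=O)c2c(O)cc(OCc3ccc(Br)cc3)c([C@H]3CCN(C)C[C@H]3O)c2o1` gives 13% and compound 2 `Cc1cc(=O)c2c(O)cc(OCc3ccc([N+](=O)[O-])cc3)c([C@H]3CCN(C)C[C@H]3O)c2o1` gives 12%, two values within the scatter of each other. Compound 3 `Cc1cc(=O)c2c(O)cc(OCc3ccccc3Br)c([C@H]3CCN(C)C[C@H]3O)c2o1` carries 2-bromophenyl in place of 4-bromophenyl on a saturated chain carbon bound to an oxygen on an aromatic ring. For the measured compounds named here, the only measured step, a number 1 percentage points lower from compound 1 to compound 2 (within the scatter), exchanges bromo for nitro and offers no direct measure of this change, so no shift beyond the scatter is expected in this assay. The expected step is a number 2 percentage points higher from compound 1 to compound 3 (within the scatter). For compound 3, the estimated value is 15%, with an expected range of 6% to 32%.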

Compound 3, percent growth inhibition at one concentration: 30%
The estimate for compound 3 lay 15 percentage points below the measured number, within the range that was stated.
By their numbers in this assay, from the lowest: compounds 2 and 1 (each within the scatter of the next); then compound 3.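

In this assay, the change from (4-bromobenzyl)oxy to (2-bromobenzyl)oxy gives a number 17 percentage points higher from compound 1 to compound 3 (beyond the scatter) with the same atoms joined differently, so the arrangement of this group affects growth inhibition in a way that the exchange of bromo for nitro did not show. The 2-bromophenyl group also separates from 4-nitrophenyl, with a number 18 percentage points higher from compound 2 to compound 3 (beyond the scatter) at the same place. No available evidence accounts for this shift.

From the compounds shown here alone, whether the higher number depends on bromo itself remains open. Plain phenyl, or 2-chlorophenyl and 2-methoxyphenyl at this place, would test that.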